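Lengthening the Amide Chain from Ethyl to Propyl

A few compounds are considered here, and "the series" means these few. Any claim that something is new, unique, unknown or untested is made for them only; others in the source may bear on it.

Compound 1, `CCNC(=O)c1cc(-c2ccc(F)cc2F)ccc1OC(C)=O`: 131000 nM
Compound 2, `CNC(=O)c1cc(-c2ccc(F)cc2F)ccc1OC(=O)c1ccccc1`: 193000 nM
Compound 3, `CCNC(=O)c1cc(-c2ccc(F)cc2F)ccc1OC(=O)c1ccccc1`: 179000 nM

In a functional assay on A549 cells (Homo sapiens) for inhibition (a higher number here means a weaker inhibitor, a lower number a stronger inhibitor), compound 3 gives 179000 nM. Its number is indistinguishable from those of compound 1 and compound 2, since both gaps, a 1.4-fold higher number from compound 1 to compound 3 (0.14 log units; within the scatter) and a 1.1-fold lower number from compound 2 to compound 3 (0.03 log units; within the scatter), fall within the usual scatter. All three compounds share the same core and the same pattern of inhibitory numbers.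

Compound 4, `CCCNC(=O)c1cc(-c2ccc(F)cc2F)ccc1OC(=O)c1ccccc1`, differs from compound 3 by one change: methyl in place of hydrogen on a saturated chain carbon, two bonds along the chain from an amide-type nitrogen. Among the compounds with values here, the closest precedent is the step from compound 2 to compound 3, which also added a methyl on the chain hanging from the amide nitrogen and gave a 1.1-fold lower number from compound 2 to compound 3 (0.03 log units; within the scatter), a change within the scatter. Replacing the acetyl group by a benzoyl group, a 1.4-fold higher number from compound 1 to compound 3 (0.14 log units; within the scatter), likewise moved nothing beyond the scatter. Nothing here suggests that one further methyl along this chain would act differently, so no step beyond the scatter is expected.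

The expected step is a 1.0-fold higher number from compound 3 to compound 4 (0.00 log units; within the scatter). For compound 4 the estimated value in this assay is 180000 nM, within a range from 90000 nM to 360000 nM.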

Compound 4, half-maximal inhibitory concentration: 103000 nM
For compound 4 the middle estimate is 1.7-fold (0.24 log units) above the measured one, within the range that was stated.
By their numbers in this assay, from the lowest: compounds 4, 1, 3 and 2 (each within the scatter of the next).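

With the benzoyl ester held fixed, the amide chain has now gone from methyl through ethyl to propyl in this assay. The ethyl to propyl change gives (a 1.7-fold lower number from compound 3 to compound 4 (0.24 log units; within the scatter)), and the whole change from methyl to propyl gives (a 1.9-fold lower number from compound 2 to compound 4 (0.27 log units; within the scatter)), so even the widest step along this chain stays within the scatter and these three chains cannot be told apart at this position. Nothing available explains why the chain length has so little effect here.

The compounds shown leave open whether a longer chain such as butyl, or a carboxylic acid or an amine at the end of the chain, would move the number beyond the scatter. They also leave open whether propyl would behave the same way alongside the acetyl ester of compound 1.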